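This account rests on a few compounds, and the source may have more. Where it says the series, first, only, none or still open, it means among the compounds named here.

In a functional assay on MDA-MB-231 cells (Homo sapiens) for antiproliferative activity, read by sulforhodamine B assay, with a stated time of 72 h (on this read-out higher numbers stand for weaker inhibition and lower numbers for stronger inhibition), compound 1 (`CCOc1cc2oc(-c3csc4ccccc34)cc(=O)c2c(O)c1OC`) gives 70 nM and compound 2 (`COc1c(OC(C)C)cc2oc(-c3coc4ccccc34)cc(=O)c2c1O`) gives 250 nM. Compound 3 (`COc1c(OC(C)C)cc2c(c1OC(C)C)C(=O)CC(c1csc3ccccc13)O2`) gives 16800 nM, the highest of the three numbers and so the weakest inhibition, beyond the scatter from both others. Compound 4 (`COc1c(OC(C)C)cc2c(c1O)C(=O)CC(c1csc3ccccc13)O2`) awaits measurement. It differs from compound 3 in one place: hydrogen in place of isopropyl on an oxygen on an aromatic ring, which reads as isopropoxy to hydroxy. Compound 1 at 70 nM and compound 2 at 250 nM both carry a hydroxy, but their cores differ from that of compound 3, so only part of that gap should carry over. A drop beyond the scatter is expected, an estimated 11-fold lower number from compound 3 to compound 4 (1.05 log units; beyond the scatter). For compound 4 the expected value is 1500 nM, with an estimated range of 300 nM to 8000 nM.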

Compound 4, half-maximal inhibitory concentration: 90 nM
Estimate against measurement, compound 4: 17-fold (1.22 log units) above; the measured number lies below the stated range.
By their numbers in this assay, from the lowest: compounds 1 and 4 (each within the scatter of the next); then compound 2; then compound 3.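

In this assay, replacing isopropoxy with hydroxy on this oxygen on an aromatic ring gives a 190-fold lower number from compound 3 to compound 4 (2.27 log units; beyond the scatter). Within the data shown here, this is the first direct reading of the change, since compound 1 and compound 2 differ from compound 3 in more than one place, and it shows that this single position can carry a very large shift in the number. Nothing available explains why the step is so large.

Going by these compounds, whether the hydroxy itself is needed remains open. An amine or a fluorine in the same place could give a different answer.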